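Inverting two ring stereocentres of compound 2

A few compounds are considered here, and "the series" means these few. Any claim that something is new, unique, unknown or untested is made for them only; others in the source may bear on it.

Measured so far in a functional assay on the whole organism with Mus musculus as the target, in the writhing test (on this read-out higher numbers stand for an effect only at larger amounts of compound and lower numbers for an effect already at smaller amounts), are two compounds:
- compound 1 `C=CCCCCOc1nsnc1C1=CCCN(C)C1` gives 0.9 mg/kg
- compound 2 `FC(F)(F)CCCSc1nsnc1[C@H]1CN2CCC[C@@H]1C2` gives 1.8 mg/kg

The two values lie within the usual scatter of each other, so the numbers set no order between compound 1 and compound 2. They share a substituted core, yet they differ in more than one place, and no single structural change can be read from this pair.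

Attention now turns to compound 3 `FC(F)(F)CCCSc1nsnc1[C@@H]1CN2CCC[C@H]1C2`, which has not yet been tested in this assay and has the same atoms and bonds as compound 2. Nothing leaves and nothing enters (the two compounds have the same atoms and bonds; at least one stereo element is drawn with a configuration in one of them and without one in the other: 2 of 3 stereo elements differ; a stereocentre at a saturated ring carbon is drawn R in compound 2 and S in compound 3; a stereocentre at a saturated ring carbon is drawn S in compound 2 and R in compound 3). One stereocentre at a saturated ring carbon goes from R to S and another from S to R.

Within the data shown here, no measured pair shows what such an inversion does in this assay, so the expectation is uncertain in both size and direction. A moderate move towards a larger effective dose seems the likeliest outcome, though no change beyond the scatter remains possible. The expected change is estimated as follows (a 2.2-fold higher number from compound 2 to compound 3 (0.35 log units; beyond the scatter)). Compound 3 is expected at 4 mg/kg (estimated range 0.7 mg/kg to 25 mg/kg).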

Compound 3, dose for half-maximal effect: > 10 mg/kg
Compound 3: a limit, no number; the forecaster's own chance of this, stated with the estimate: 10%; middle value at least 2.5-fold (0.39 log units) away from the limit.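

In this assay compound 3 gives > 10 mg/kg, which is a limit of the assay and not a number. Among these compounds, the inversion of the two ring stereocentres is the first single change that can be read here: with atoms and bonds unchanged, it gives an at least 5.5-fold higher number from compound 2 to compound 3 (0.74 log units; beyond the scatter), so in this pair the configuration at these saturated ring carbons alone separates the two results in this assay. The full size of the step remains unknown because of the following: the limit of > 10 mg/kg in this assay, at which 1 of the 3 values shown sits.

The compounds shown do not tell whether one of the two centres or both together account for the step, or whether inversion would have a similar result with another side chain, such as a longer chain or one carrying a nitrile or a carboxylic acid. The comparison also has to be read with one feature of the drawn structures in mind: the fact that one of compounds 2 and 3 is drawn with a defined configuration and the other without, at the place where they differ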